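The compounds below may be only part of what the source reports. "The series", "measured", "known", "first", "only" and "open" are said of these compounds alone.

Measured so far in a functional assay on A549 cells (Homo sapiens) for antiproliferative activity, read by MTT assay, with a stated time of 48 h; a higher number here means a weaker inhibitor, a lower number a stronger inhibitor:
compound 1 `C/C(=C\CC/C(C)=C/CC[C@@H]1[C@@]2(C)CCC(=O)C(C)(C)[C@H]2CC[C@@]1(C)O)CC/C=C(\C)C(=O)OCc1cn(-c2ccccc2C)nn1` gives > 150000 nM, a limit of the assay.
compound 2 `C/C(=C\CC/C(C)=C/CC[C@@H]1[C@@]2(C)CCC(=O)C(C)(C)[C@H]2CC[C@@]1(C)O)CC/C=C(\C)C(=O)OCc1cn([C@@H]2C[C@@H](n3cc(C)c(=O)[nH]c3=O)O[C@H]2CO)nn1` gives 35000 nM.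
compound 3 `C/C(=C\CC/C(C)=C/CC[C@@H]1[C@@]2(C)CCC(=O)C(C)(C)[C@H]2CC[C@@]1(C)O)CC/C=C(\C)C(=O)O` gives > 150000 nM, a limit of the assay.

Compound 1 stands at the limit of > 150000 nM in this assay, at which 2 of the 3 values shown sit, so no number is known for it, only a limit. Among the measured compounds shown here, compound 2 is the one compound of the three with a number.

Compound 4 `COc1cccc(-n2cc(COC(=O)/C(C)=C/CC/C(C)=C/CC/C(C)=C/CC[C@@H]3[C@@]4(C)CCC(=O)C(C)(C)[C@H]4CC[C@@]3(C)O)nn2)c1` differs from compound 1 by 3-methoxyphenyl in place of 2-methylphenyl on an aromatic nitrogen. For the measured compounds named here, no step between measured compounds is known against which this change can be gauged, and the start point is itself a limit. In this assay the step from the limit of compound 1 is expected to be none beyond the scatter, a number no higher from compound 1 to compound 4 (the limit leaves the size open). Compound 4 is therefore expected at 150000 nM, in the range 60000 nM to 400000 nM, and most likely the assay will again report only a limit.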

Compound 4, half-maximal inhibitory concentration: > 150000 nM
Compound 4: a limit, no number (the forecaster's own chance of this, stated with the estimate: 70%); the middle value sits exactly at the limit.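

Among the compounds shown here, compound 1 and compound 4 both return only a limit, so no step between them can be read: the limit of > 150000 nM in this assay, at which 3 of the 4 values shown sit. Left open is whether 3-methoxyphenyl and 2-methylphenyl on an aromatic nitrogen differ at all in antiproliferative activity.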